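Trading the Aryl Ketone for a Methyl Ketone

The source may hold more compounds than are shown below. What is called first, only, known or untested is meant among the compounds shown, and "the series" means these compounds.

Compound 1, `CCOC(=O)c1cc(-c2ccc(Cl)cc2)n(-c2ccc(S(N)(=O)=O)cc2)c1C`: 3%
Compound 2, `Cc1cc(C(=O)c2cc(-c3ccc(Cl)cc3)n(-c3ccc(S(N)(=O)=O)cc3)c2C)ccc1Cl`: 38%
Compound 3, `COc1ccc(F)cc1C(=O)c1cc(-c2ccc(Cl)cc2)n(-c2ccc(S(N)(=O)=O)cc2)c1C`: 45%

In an ADME assay on microsomes from liver (Rattus norvegicus) for metabolic stability, with a stated time of 30 min (on this read-out higher numbers stand for a more stable compound and lower numbers for a less stable compound), compound 3 gives 45%, the highest of the three numbers. Compound 2 gives 38%, and the step of a number 7 percentage points higher from compound 2 to compound 3 (within the scatter) lies within the scatter, so the two cannot be ranked against each other. Compound 1 gives 3%, and the step of a number 42 percentage points higher from compound 1 to compound 3 (beyond the scatter) is well beyond the scatter.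

Compound 4, `CC(=O)c1cc(-c2ccc(Cl)cc2)n(-c2ccc(S(N)(=O)=O)cc2)c1C`, differs from compound 3 in one place: methyl in place of 5-fluoro-2-methoxyphenyl on a carbonyl carbon. Among the measured compounds shown here, two measured steps bear on this change, a number 35 percentage points higher from compound 1 to compound 2 (beyond the scatter) and a number 42 percentage points higher from compound 1 to compound 3 (beyond the scatter). In both an aromatic ring enters on the carbonyl carbon in place of a small ethoxy group, and in both the number rises by a large amount. The step to compound 4 runs the other way: the aromatic ring leaves and a one-carbon methyl enters. For the measured compounds named here, no measured pair shows exactly this exchange, but compound 1, the only measured compound with a small group on that carbon, gives 3%. A large fall is therefore expected, with the step of a number 35 percentage points lower from compound 3 to compound 4 (beyond the scatter) estimated as beyond the scatter. Compound 4 is expected to give about 10%, between 2% and 30%.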

Compound 4, percent of the compound remaining: 64%
The estimate for compound 4 lay 54 percentage points below the measured number, and the stated range ends below it.
By their numbers in this assay, from the lowest: compound 1; then compounds 2 and 3 (each within the scatter of the next); then compound 4.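

Methyl on the carbonyl carbon does better than either aromatic group in this assay, giving a number 19 percentage points higher from compound 3 to compound 4 (beyond the scatter) and a number 26 percentage points higher from compound 2 to compound 4 (beyond the scatter), so an aromatic ring at this position is not needed for a high number. Neither compound 1 nor compound 4 carries an aromatic ring on that carbon, yet methyl in place of ethoxy gives a number 61 percentage points higher from compound 1 to compound 4 (beyond the scatter), which ties the low number of compound 1 to the ethoxy group itself and not to the missing ring. The numbers at this position therefore do not simply follow the size of the group: the compounds with aromatic groups sit in the middle, with ethoxy lowest and methyl highest.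

Nothing measured here explains why the groups fall in this order. As far as these compounds go, it also remains open whether a longer chain such as ethyl or propyl on the carbonyl carbon would hold the number of compound 4, and whether an amine attached there, forming an amide, would behave more like methyl or like ethoxy.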